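This account rests on a few compounds, and the source may have more. Where it says the series, first, only, none or still open, it means among the compounds named here.

Measured so far:
- compound 1 `Nc1nc(N)c2cc(CSC(=S)N3CCN(C4CCCCC4)CC3)ccc2n1`: 8400 nM
- compound 2 `Nc1nc(N)c2cc(CSC(=S)N3CCN(c4ccccc4Cl)CC3)ccc2n1`: 5490 nM
- compound 3 `Nc1nc(N)c2cc(CSC(=S)N3CCN(c4ccc(F)cc4F)CC3)ccc2n1`: 5150 nM

These three compounds share one core and differ only in the group on an amine nitrogen in a ring. In a functional assay on HCT-116 cells (Homo sapiens) for antiproliferative activity, read by MTT assay, with a stated time of 72 h (on this read-out lower numbers stand for stronger inhibition and higher numbers for weaker inhibition), compound 3 gives 5150 nM, a number that cannot be told apart from those of the other two, since all three agree within the usual scatter of repeated measurements.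

The next compound is compound 4 `Nc1nc(N)c2cc(CSC(=S)N3CCN(c4ccc([N+](=O)[O-])cc4)CC3)ccc2n1`, with 4-nitrophenyl in place of 2,4-difluorophenyl at that same spot: 4-nitrophenyl in place of 2,4-difluorophenyl on an amine nitrogen in a ring.

Going by the values given here, no measured compound carries a 4-nitrophenyl, so the evidence is indirect. Three measured steps change this same group: a 1.5-fold lower number from compound 1 to compound 2 (0.18 log units; within the scatter), a 1.6-fold lower number from compound 1 to compound 3 (0.21 log units; within the scatter) and a 1.1-fold lower number from compound 2 to compound 3 (0.03 log units; within the scatter). The last is closest in kind, since one substituted phenyl replaces another. Even swapping cyclohexyl for an aromatic ring did not move the number beyond the scatter, so no clear change is expected in this assay here, in either direction.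

The expected change is a 1.1-fold higher number from compound 3 to compound 4 (0.03 log units; within the scatter). For compound 4 the estimate is 5500 nM, with an expected range of 2500 nM to 11000 nM.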

Compound 4, half-maximal inhibitory concentration: 4680 nM
For compound 4 the middle estimate is 1.2-fold (0.07 log units) above the measured one; the range from low to high includes it.
By their numbers in this assay, from the lowest: compounds 4, 3, 2 and 1 (each within the scatter of the next).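

In this assay, 4-nitrophenyl brings hydrogen-bond acceptors where 2,4-difluorophenyl has none, yet the swap gives a 1.1-fold lower number from compound 3 to compound 4 (0.04 log units; within the scatter) and so no readable change, and the swap from the chlorine-bearing ring gives a 1.2-fold lower number from compound 2 to compound 4 (0.07 log units; within the scatter) with the same outcome. Set against the saturated cyclohexyl group, the picture holds, with a 1.8-fold lower number from compound 1 to compound 4 (0.25 log units; within the scatter) as the step, so cyclohexyl and the three substituted phenyl rings cannot be told apart at this amine nitrogen, even with a nitro group in place of halogens. Nothing in the available data explains why such different groups give numbers that cannot be separated here.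

From the compounds shown here alone, all four compounds carry a ring on that nitrogen, so it stays open whether a small methyl, a longer alkyl chain, or a phenyl bearing a carboxylic acid or an amine would move the number beyond the scatter. The rest of the shared core is identical throughout, which leaves open what a change elsewhere in the molecule would do.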